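The source may hold more compounds than are shown below. What is called first, only, known or untested is meant among the compounds shown, and "the series" means these compounds.

Working notes on the series. All four compounds share one core bearing two ester-linked aryl groups; only the aryl on one carbonyl carbon changes. Compound 1 `CC(=O)Oc1ccccc1C(=O)O[C@H]1CO[C@H]2[C@@H]1OC[C@H]2OC(=O)c1ccc(O)cc1` carries 4-hydroxyphenyl there, and in an ADME assay on a cell-free system (plasma, Homo sapiens) for metabolic stability, with Plasma (Rattus norvegicus) as the target, read by HPLC, at pH 7.4 (a lower number here means that the compound disappears faster, a higher number that the compound lasts longer), compound 1 gives 0.0198 h, the lowest of the three numbers in hand. Compound 2 `CC(=O)Oc1ccccc1C(=O)O[C@H]1CO[C@H]2[C@@H]1OC[C@H]2OC(=O)c1cccc(C)c1` carries 3-methylphenyl, and compound 2 gives 0.165 h. Compound 3 `CC(=O)Oc1ccccc1C(=O)O[C@H]1CO[C@H]2[C@@H]1OC[C@H]2OC(=O)c1ccncc1` carries pyridin-4-yl, and compound 3 gives 0.0617 h. Both measured steps away from compound 1 raise the number: an 8.3-fold higher number from compound 1 to compound 2 (0.92 log units; beyond the scatter) and a 3.1-fold higher number from compound 1 to compound 3 (0.49 log units; beyond the scatter); the two replacements stand apart by a 2.7-fold lower number from compound 2 to compound 3 (0.43 log units; beyond the scatter).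

Compound 4 `CC(=O)Oc1ccccc1C(=O)O[C@H]1CO[C@H]2[C@@H]1OC[C@H]2OC(=O)c1ccc(CO[N+](=O)[O-])cc1` is the next step from compound 1: (nitrooxy)methyl in place of hydroxy on an aromatic carbon. Among the compounds with values here, no measured step replaces hydroxy with (nitrooxy)methyl, so the bearing of the data is indirect. Each replacement of hydroxy measured so far moved the number up, by modest amounts, and the entering group resembles neither of them. A modest upward step in this assay is therefore expected, with wide uncertainty, and the expected step is put at a 3.0-fold higher number from compound 1 to compound 4 (0.48 log units; beyond the scatter). Compound 4 is estimated at 0.06 h, with a range of 0.02 h to 0.2 h.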

Compound 4, half-life: 0.1 h
Compound 4: the middle estimate sits 1.7-fold (0.22 log units) below what was measured; measured number inside the range.
By their numbers in this assay, from the lowest: compound 1; then compounds 3, 4 and 2 (each within the scatter of the next, the first and the last beyond it).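

In this assay, the hydroxy group on the aromatic carbon para to a large group gives way to (nitrooxy)methyl with a 5.1-fold higher number from compound 1 to compound 4 (0.70 log units; beyond the scatter), so all three aryl replacements now lie beyond the scatter above compound 1, and a substituent at this place on the phenyl ring does not by itself keep the number as low as in compound 1. The new group does not separate compound 4 from either of the other replacements, with a 1.6-fold higher number from compound 3 to compound 4 (0.21 log units; within the scatter) and a 1.7-fold lower number from compound 2 to compound 4 (0.22 log units; within the scatter), both within the scatter, even though compound 2 and compound 3 remain distinct from each other. No supporting measurement bears on why the number moves at this position.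

Still open, from the compounds shown here alone, is whether the step from compound 1 follows from losing the hydroxy group or from the particular group that enters, a question that a plain methyl, a methoxy or a hydroxymethyl group at the same place would help to settle. Also open, going by these compounds, is how an amine or a carboxylic acid at this place would read in this assay.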